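Adding a Second Chloro to an Inactive Sulfonamide

The source may report more compounds than this note shows. Statements on the series, on what has been measured and on what is new or still open speak of the compounds shown alone.

Measured compounds:
Compound 1 `CC1CCN(C2CCN(S(=O)(=O)c3cccnc3F)CC2)CC1` gives > 5000 nM in a functional assay on DLD-1 cells (Homo sapiens) for antiproliferative activity, read by CellTiter-Glo, with a stated time of 72 h (a higher number here means a weaker inhibitor, a lower number a stronger inhibitor), which is a limit of the assay.
Compound 2 `CC1CCN(C2CCN(S(=O)(=O)c3cccc(Cl)c3)CC2)CC1` gives > 5000 nM in this assay, also a limit.

The step that the two limits leave unreadable from compound 1 to compound 2 cannot be read, because both values sit at the limit of > 5000 nM in this assay, at which 2 of the 2 values shown sit. Compound 2 therefore stands only at the limit of what this assay reports, with no number behind it. Compound 3 `CC1CCN(C2CCN(S(=O)(=O)c3cc(Cl)cc(Cl)c3)CC2)CC1` differs from compound 2 by chloro in place of hydrogen on an aromatic carbon. For the measured compounds named here, no measured step bears on this change, so no direction can be drawn from the data; with compound 2 at its limit, compound 3 is expected to remain weak. The expected step is a step that the limit leaves unreadable from compound 2 to compound 3. Compound 3 is estimated at 8000 nM, within 3000 nM to 30000 nM.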

Compound 3, half-maximal inhibitory concentration: 3400 nM
Compound 3: the middle estimate sits 2.4-fold (0.37 log units) above what was measured; low and high end bracket the measured number.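

Compound 3 is the only one of the three with a readable number in this assay: it gives 3400 nM. A chloro in place of hydrogen on this aromatic carbon gives an at least 1.4-fold lower number from compound 2 to compound 3 (0.16 log units; that floor lies within the scatter), and 3,5-dichlorophenyl in place of 2-fluoropyridin-3-yl gives an at least 1.4-fold lower number from compound 1 to compound 3 (0.16 log units; that floor lies within the scatter). The true size of both steps cannot be read, because the starting values are limits rather than numbers: the limit of > 5000 nM in this assay, at which 2 of the 3 values shown sit.

On these data alone, whether a bromo, a methoxy or a trifluoromethyl on this carbon would lower the number further remains open. So does whether the change would hold on another core.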